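This account rests on a few compounds, and the source may have more. Where it says the series, first, only, none or still open, it means among the compounds named here.

Measured so far:
- Compound 1, `Cn1c(NN)nc(-c2ccco2)c(C#N)c1=O`: 65 ug/mL
- Compound 2, `CSc1nc(-c2ccco2)c(C#N)c(=O)n1C`: 108 ug/mL
- Compound 3, `Cn1c(NN)nc(-c2ccc(Cl)cc2)c(C#N)c1=O`: 59 ug/mL

The numbers come from a functional assay, with a stated time of 150 min; a higher number here means a weaker inhibitor, a lower number a stronger inhibitor. Compound 3 has the lowest number of the three, but its nearest neighbour, compound 1, gives 65 ug/mL, and the gap between them lies within the scatter, as does the gap to compound 2, so the three compounds cannot be told apart on these numbers.

Compound 4 is `COc1ccc(-c2nc(NN)n(C)c(=O)c2C#N)cc1`. It differs from compound 3 in one place: methoxy in place of chloro on an aromatic carbon. For the measured compounds named here, the only measured step, a 1.7-fold higher number from compound 1 to compound 2 (0.22 log units; within the scatter), concerns a change on the shared core, not on the ring that carries the chloro group, and it stayed within the scatter. Going by the values given here, no measured pair shows what exchanging one group for another on that ring does, so there is no direct guide for this change. Among the compounds with values here, the compounds measured so far all sit close together, and nothing in them points to a move in either direction.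

Compound 4 is therefore expected to give about 65 ug/mL in this assay, between 30 ug/mL and 140 ug/mL, which means an expected step of a 1.1-fold higher number from compound 3 to compound 4 (0.04 log units; within the scatter), no larger than the scatter.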

Compound 4, half-maximal inhibitory concentration: 56 ug/mL
Beside the measured number, compound 4's estimate is 1.2-fold (0.06 log units) above it; the range from low to high includes it.
By their numbers in this assay, from the lowest: compounds 4, 3, 1 and 2 (each within the scatter of the next).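

In this assay, for the compounds shown here, putting methoxy in place of chloro on the aromatic carbon para to a large group gives a 1.1-fold lower number from compound 3 to compound 4 (0.02 log units; within the scatter), the first measured exchange of one group for another on this ring. Going by these compounds alone, the entering group has 2 heavy atoms and 1 hydrogen-bond acceptor, while the leaving group has 1 heavy atom and no hydrogen-bond acceptor, yet this difference produces no step that can be told from the scatter, so the position accepts this particular exchange without a readable change in the number. No measurement at hand explains why these two groups read alike.

Chloro and methoxy are only two groups, so it remains open whether an amine, a carboxylic acid or a longer chain such as butoxy at this position would also stay within the scatter or would produce a clear step. On these data alone, it is also open whether methylsulfanyl in place of aminoamino, which gave a 1.7-fold higher number from compound 1 to compound 2 (0.22 log units; within the scatter), would give a step of similar size in a compound carrying the methoxy group.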